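The source may report more compounds than this note shows. Statements on the series, on what has been measured and on what is new or still open speak of the compounds shown alone.

Measured compounds:
Compound 1, `COc1ccc(C2Nc3ccccc3C(=O)N2Cc2ccccc2)cc1COc1ccccc1`, which in a functional assay on HEK-EM293 cells for agonist activity at Thyrotropin receptor (Homo sapiens), read by ELISA and cAMP accumulation, with a stated time of 1 h (on this read-out higher numbers stand for larger maximal responses and lower numbers for smaller maximal responses), gives 25.6%.
Compound 2, `COc1ccc(C2Nc3ccccc3C(=O)N2Cc2ccccc2)cc1COc1cccc(NC(C)=O)c1`, which in this assay gives 24.8%.

Going by the values given here, compound 2 is one of only two measured compounds here, and its nearest neighbour is compound 1, from which it differs by acetamido in place of hydrogen on an aromatic carbon; the two values lie within the scatter of each other, as a number 0.8 percentage points lower from compound 1 to compound 2 (within the scatter) shows. Compound 3, `COc1ccc(C2Nc3ccccc3C(=O)N2Cc2ccccc2)cc1COc1ccc(C#N)cc1`, has not yet been measured. Its difference from compound 2 is 4-cyanophenyl in place of 3-acetamidophenyl on an oxygen on a saturated carbon. Among the compounds with values here, the one measured step bears on it only in part: it shows that adding or removing the acetamido group left the maximal response unchanged within the scatter, while no measured pair speaks to the cyano group. Compound 3 is therefore expected to give 25% in this assay, between 14% and 38%, a step of a number 0.2 percentage points higher from compound 2 to compound 3 (within the scatter) that is estimated not to exceed the scatter.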

Compound 3, largest response reached (Emax), in percent of the reference or control that the assay uses: 11.7%
Compound 3: middle estimate off by 13.3 percentage points, on the high side; measured number outside the range, below it.
By their numbers in this assay, from the lowest: compound 3; then compounds 2 and 1 (each within the scatter of the next).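

The phenoxy ring of the shared core does respond to substitution in this assay: an earlier step, acetamido in place of hydrogen, had stayed within the scatter, whereas cyano in place of hydrogen on an aromatic carbon gives a number 13.9 percentage points lower from compound 1 to compound 3 (beyond the scatter). Exchanging 3-acetamidophenyl for 4-cyanophenyl on the oxygen on a saturated carbon gives a step of similar size, a number 13.1 percentage points lower from compound 2 to compound 3 (beyond the scatter), so the lower maximal response goes with the cyano-bearing ring in both comparisons. Nothing available accounts for this fall in response.

The compounds shown leave open whether the step follows from the cyano group itself or also from where it sits on the ring. They also leave open how an amine or a carboxylic acid on that ring would read in this assay.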